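Trifluoromethyl in Place of Phenyl on a Dichloroacetamide

The compounds below may be only part of what the source reports. "The series", "measured", "known", "first", "only" and "open" are said of these compounds alone.

Three dichloroacetamides have been tested in a functional assay on KB 3-1 cells (Homo sapiens) for cytotoxicity, read by MTT assay, with a stated time of 68 h; a lower number here means a stronger inhibitor, a higher number a weaker inhibitor. Compound 1 `CSc1cccc(-c2cc(NC(=O)C(Cl)Cl)cc(-c3cccc(SC)c3)c2)c1` gives only a limit, > 30000 nM, which is the limit of > 30000 nM in this assay, at which 1 of the 3 values shown sits. Compound 2 `O=C(Nc1cccc(-c2ccc(-c3ccccc3)cc2)c1)C(Cl)Cl` likewise gives only a limit, > 50000 nM. Compound 3 `O=C(Nc1cccc(-c2cccc(Cl)c2)c1)C(Cl)Cl` also reaches no number, only the limit > 50000 nM, which is the limit of > 50000 nM in this assay, at which 2 of the 3 values shown sit. Compound 2 therefore stands with the others where no number is read in this assay. Compound 4 `O=C(Nc1cccc(-c2ccc(C(F)(F)F)cc2)c1)C(Cl)Cl` is not yet measured; it differs from compound 2 by trifluoromethyl in place of phenyl on an aromatic carbon. Among the compounds with values here, no step between measured compounds is known, so no size of change can be drawn from them. With every measured value a limit, the step of a number no higher from compound 2 to compound 4 (the limit leaves the size open) is expected to stay within the scatter. Compound 4 is estimated at 50000 nM, between 20000 nM and 120000 nM in this assay, most likely again only a limit.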

Compound 4, half-maximal inhibitory concentration: > 50000 nM
Compound 4: a limit, no number; the forecaster's own chance of this, stated with the estimate: 80%; the middle value lies on the limit itself.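

Within the data shown here, compound 2 and compound 4 each give only a limit in this assay, so no step between them can be read. The compounds shown leave open how trifluoromethyl and phenyl compare, and which change to these dichloroacetamides would give a readable number.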